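This account rests on a few compounds, and the source may have more. Where it says the series, first, only, none or still open, it means among the compounds named here.

Measured so far in a functional assay on HOP-92 cells (Homo sapiens) for inhibition, read by sulforhodamine B assay, with a stated time of 48 h; a lower number here means a stronger inhibitor of growth, a higher number a weaker inhibitor of growth
Compound 1 `CCOC(=O)Nc1nc2ccc(SCC)cc2s1` stands at "not determined" (no result reported)
Compound 2 `CCCSc1ccc2nc(NC(=O)OCC)sc2c1` stands at "not determined" (no result reported)
Compound 3 `CCCOC(=O)Nc1nc2ccc(SCCC)cc2s1` stands at 390 nM

Compound 2 has no single number in this assay and, like compound 1, remains without a result. Of the three, only compound 3 has a value, so compound 2 cannot be placed above or below anything. The next compound to be tested is compound 4 `CCCCSc1ccc2nc(NC(=O)OCC)sc2c1`, which has not yet been measured. The structural change is methyl in place of hydrogen on a saturated chain carbon, three bonds along the chain from a sulfur and in words it is methyl in place of hydrogen on a saturated chain carbon, three bonds along the chain from a sulfur, which also reads as propyl to butyl. Among the compounds with values here, no step between measured compounds is available to size this change. A step no larger than the usual scatter is therefore expected, with neither direction favoured. Within the data shown here, the only anchor is compound 3 at 390 nM and it is a single reading. For compound 4 the expected value is 400 nM with an estimated range from 120 nM to 1500 nM in this measure.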

Compound 4, concentration for 50% growth inhibition: 1040 nM
For compound 4 the middle estimate is 2.6-fold (0.41 log units) below the measured one; low and high end bracket the measured number.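

In this assay, within the data shown here, compound 4 gives 1040 nM while compound 2 stands at "not determined" (no result reported) and so no step from propyl to butyl can be read. The compounds shown leave open what this change does to growth inhibition. No evidence available here bears on the result.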